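The compounds below may be only part of what the source reports. "The series", "measured", "known", "first", "only" and "open" are said of these compounds alone.

Of the compounds shown here, two have numbers so far in a functional assay on QG-56 cells (Homo sapiens) for antiproliferative activity; a lower number here means a stronger inhibitor, a higher number a weaker inhibitor. Compound 1 (`Cn1cncc1[C@@](N)(c1ccc(C#N)cc1)c1cc2cc([N+](=O)[O-])cc(-c3ccccc3)c2o1`) gives 5.9 nM, and compound 2 (`Cn1cncc1C(O)(c1ccc(C#N)cc1)c1cc2cc(C#N)cc(-c3ccccc3)c2o1`) gives 14.5 nM. Compound 2 therefore holds the higher of the two numbers, making it the weaker inhibitor of the pair, and the gap between them lies beyond the usual scatter.

The next entry is compound 3 (`Cn1cncc1C(O)(c1ccc(C#N)cc1)c1cc2cc([N+](=O)[O-])cc(-c3ccccc3)c2o1`), which has nitro in place of cyano on an aromatic carbon of compound 2: nitro in place of cyano on an aromatic carbon. For the measured compounds named here, no measured pair isolates this exchange, so its size in this assay remains unknown and any expectation rests on two data points. Going by the values given here, the only measured compound carrying nitro, compound 1, gives 5.9 nM, which points weakly toward a lower number than that of compound 2. A modest shift in that direction is expected, probably not beyond the scatter, and a flat result would be no surprise. The expected step of a 1.5-fold lower number from compound 2 to compound 3 (0.16 log units; within the scatter) is accordingly small. Compound 3 is estimated at 10 nM, with an expected range of 4 nM to 25 nM.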

Compound 3, half-maximal inhibitory concentration: 1480 nM
Estimate against measurement, compound 3: 150-fold (2.17 log units) below; the whole stated range lies below it.
By their numbers in this assay, from the lowest: compound 1; then compound 2; then compound 3.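

In this assay, the aromatic carbon para to a fused ring and meta to the phenyl group proves highly sensitive to this exchange: nitro in place of cyano gives a 100-fold higher number from compound 2 to compound 3 (2.01 log units; beyond the scatter) in the hydroxyl-bearing pair. The nitro group alone does not account for a high number: compound 3 gives 1480 nM, while with an amine in place of the hydroxyl of compound 3 and nitro retained, compound 1 gives 5.9 nM. For the compounds shown here, nothing available bears on why this single exchange moves the number so far.

The compounds shown leave open whether the step from nitrile to nitro is of similar size when the amine replaces the hydroxyl, as this rests on one pair only. They also leave open whether other groups on this aromatic carbon, such as chlorine, trifluoromethyl or a carboxylic acid, give numbers closer to that of the nitrile or to that of the nitro group in the hydroxyl-bearing compounds.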